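Nitro to methoxy swap on two related cores

The compounds below may be only part of what the source reports. "The series", "measured", "known", "first", "only" and "open" are said of these compounds alone.

Measured so far in a functional assay on MCF7 cells (Homo sapiens) for inhibition, read by MTT assay, with a stated time of 72 h; a lower number here means a stronger inhibitor, a higher number a weaker inhibitor:
compound 1, `CCN1C(=O)N(CC)C2C1NC(=S)N2/N=C/C=C/c1ccccc1[N+](=O)[O-]`: 43900 nM
compound 2, `CCN1C(=O)N(CC)C2C1NC(=S)N2/N=C/C=C/c1ccccc1OC`: > 100000 nM
compound 3, `CCN1C(=O)N(CC)C2C1N=C(SC)N2/N=C/C=C/c1ccccc1[N+](=O)[O-]`: 66700 nM

Compound 1 and compound 2 share one core, compound 3 and compound 4 another; the difference between the two cores is not broken down here. Compound 2 carries the change methoxy in place of nitro on an aromatic carbon relative to compound 1. The value of compound 2 in this assay is a limit, not a number, as stated in the limit of > 100000 nM in this assay, at which 1 of the 3 values shown sits. That gives an at least 2.2-fold higher number from compound 1 to compound 2 (0.35 log units; beyond the scatter). Compound 3 and compound 1 lie within the scatter of each other in this assay, so nothing is read from that pair.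

Compound 4, `CCN1C(=O)N(CC)C2C1N=C(SC)N2/N=C/C=C/c1ccccc1OC`, has not been measured. It differs from compound 3 by methoxy in place of nitro on an aromatic carbon, the same change at the same place as between compound 1 and compound 2. The expected step is a 2.4-fold higher number from compound 3 to compound 4 (0.38 log units; beyond the scatter), resting on an at least 2.2-fold higher number from compound 1 to compound 2 (0.35 log units; beyond the scatter) and on the value of compound 3, 66700 nM. Compound 4 is therefore estimated at 160000 nM in this assay, with the range expected between 70000 nM and 400000 nM, and a limit rather than a number is the likelier report.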

Compound 4, half-maximal inhibitory concentration: 34600 nM
For compound 4 the middle estimate is 4.6-fold (0.67 log units) above the measured one, outside the stated range (below it).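

In this assay, going by these compounds alone, methoxy in place of nitro on the core of compound 3 gives a 1.9-fold lower number from compound 3 to compound 4 (0.29 log units; within the scatter), so on this core the change leaves no step that can be read as real. The effect seen on the core of compound 1 therefore does not carry over to the core of compound 3, and the two steps differ: the same change on two cores in this assay, an at least 2.2-fold higher number (0.35 log units; beyond the scatter) from compound 1 to compound 2 and a 1.9-fold lower number (0.29 log units; within the scatter) from compound 3 to compound 4, at least 4.3-fold (0.64 log units) apart, beyond the scatter of two such steps With only one pair on each core, this does not show which difference between the cores goes with the gap, or whether it would recur on another core, and compound 2 holds a limit rather than a number: the limit of > 100000 nM in this assay, at which 1 of the 4 values shown sits.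

The compounds shown leave open how the two cores compare when the 2-nitrophenyl or 2-methoxyphenyl group gives way to a ring carrying another group, such as an amine or a carboxylic acid. Also open, going by these compounds, is whether a longer chain in place of the ethyl groups would alter these numbers in this assay.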